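A few compounds are considered here, and "the series" means these few. Any claim that something is new, unique, unknown or untested is made for them only; others in the source may bear on it.

In a functional assay on MOLT-4 cells (Homo sapiens) for inhibition (a higher number here means a weaker inhibitor, a lower number a stronger inhibitor), compound 1 `CCC(C)C(NC(=O)NO)C(=O)NC(c1ccccc1)c1ccccc1` gives 56000 nM and compound 2 `CCC(C)C(NC(=O)n1nnc2ccccc21)C(=O)NC(c1ccccc1)c1ccccc1` gives 79000 nM. The change between them, a 1.4-fold higher number from compound 1 to compound 2 (0.15 log units; within the scatter), leaves compound 2 level with compound 1. Compound 3 `CC(C)C(NC(=O)NO)C(=O)NC1CCCC1`, which has no phenyl group and differs in other places too, reports only a limit, > 200000 nM. Compound 4 `CCC(C)C(NC(=O)n1nnc2ccccc21)C(=O)NCc1ccccc1` differs from compound 2 by hydrogen in place of phenyl on a saturated chain carbon bound to an amide-type nitrogen and an aromatic carbon. Among the compounds with values here, no measured step covers this change, since the only one, a 1.4-fold higher number from compound 1 to compound 2 (0.15 log units; within the scatter), falls on a carbonyl carbon and gives no size for it. The limit seen for compound 3 offers only a loose hint towards a higher number, so a modest step is expected, a 1.4-fold higher number from compound 2 to compound 4 (0.14 log units; within the scatter). For compound 4 the estimated value is 110000 nM, with an expected range from 45000 nM to 200000 nM.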

Compound 4, half-maximal inhibitory concentration: 96000 nM
Compound 4: the middle estimate sits 1.1-fold (0.06 log units) above what was measured; measured number inside the range.
By their numbers in this assay, from the lowest: compounds 1, 2 and 4 (each within the scatter of the next). At a limit, above all of these: compound 3.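

In this assay, hydrogen in place of phenyl on a saturated chain carbon bound to an amide-type nitrogen and an aromatic carbon gives a 1.2-fold higher number from compound 2 to compound 4 (0.08 log units; within the scatter). Within the data shown here, this is the first measured change at this position, and it shows that one phenyl can be lost without a shift beyond the scatter. Compound 3 stands alone at a limit, which is not a number: the limit of > 200000 nM in this assay, at which 1 of the 4 values shown sits.

As far as these compounds go, what remains open is whether a methyl group, an amine or a longer chain at this carbon would move the number. Also open, from the compounds shown here alone, is what the loss of the remaining phenyl would do.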